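Acyl chain length and buffer solubility in three esters

The compounds below may be only part of what the source reports. "The series", "measured", "known", "first", "only" and "open" are said of these compounds alone.

Measured compounds:
compound 1 `CC(C)(C)C(=O)OC[C@H]1O[C@@H](n2cnc3c(N)ncnc32)[C@@H](O)[C@@H]1O` gives 7000 ug/mL
compound 2 `CCCCCCCC(=O)OC[C@H]1O[C@@H](n2cnc3c(N)ncnc32)[C@@H](O)[C@@H]1O` gives 100 ug/mL
compound 3 `CC(=O)OC[C@H]1O[C@@H](n2cnc3c(N)ncnc32)[C@@H](O)[C@@H]1O` gives 6600 ug/mL

The read-out is a physicochemical assay for solubility, in phosphate buffer, with a stated time of 16 h; on this read-out higher numbers stand for higher solubility and lower numbers for lower solubility. Compound 2 stands lowest of the three numbers; its nearest neighbour is compound 3, see a 66-fold higher number from compound 2 to compound 3 (1.82 log units; beyond the scatter), and the furthest is compound 1, see a 70-fold lower number from compound 1 to compound 2 (1.85 log units; beyond the scatter). Compound 1 and compound 3 sit within the scatter of each other, see a 1.1-fold lower number from compound 1 to compound 3 (0.03 log units; within the scatter).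

The step from compound 2 to the unmeasured compound 4 `CCCC(=O)OC[C@H]1O[C@@H](n2cnc3c(N)ncnc32)[C@@H](O)[C@@H]1O` is hydrogen in place of butyl on a saturated chain carbon, three bonds along the chain from a carbonyl carbon. The two steps that bear on it are those that shorten or change the chain on the carbonyl carbon: a 66-fold higher number from compound 2 to compound 3 (1.82 log units; beyond the scatter) and a 70-fold lower number from compound 1 to compound 2 (1.85 log units; beyond the scatter), both large and both pointing toward higher numbers for the shorter chain. The change to compound 4 removes part of the chain rather than all of it, so the expected step in this assay is upward from compound 2, large but likely smaller than either of the two measured steps.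

Compound 4 is therefore estimated at 3000 ug/mL, with a range of 1000 ug/mL to 7000 ug/mL, which would mean an expected step of a 30-fold higher number from compound 2 to compound 4 (1.48 log units; beyond the scatter).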

Compound 4, solubility: 16100 ug/mL
For compound 4 the middle estimate is 5.4-fold (0.73 log units) below the measured one; the measured number lies above the stated range.
By their numbers in this assay, from the lowest: compound 2; then compounds 3 and 1 (each within the scatter of the next); then compound 4.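

In this assay the numbers no longer run in one direction with chain size on the carbonyl carbon: propyl stands above methyl, a 2.4-fold higher number from compound 3 to compound 4 (0.39 log units; beyond the scatter), while the gap to the heptyl chain widens, a 160-fold higher number from compound 2 to compound 4 (2.21 log units; beyond the scatter). The unbranched propyl also stands above the tert-butyl group, a 2.3-fold higher number from compound 1 to compound 4 (0.36 log units; beyond the scatter), so compound 4 holds the highest number of the four, with all three of its steps beyond the scatter, and the large change in this series falls between propyl and heptyl, not between methyl and propyl. No supporting data are available to account for this order of the four esters.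

Still open, going by these compounds, is where between propyl and heptyl the numbers begin to fall, a point that a pentyl chain on the carbonyl carbon would help to place. Also open, on these data alone, is whether an amine or a carboxylic acid carried on the heptyl chain would move compound 2 away from the bottom of the series.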